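This account rests on a few compounds, and the source may have more. Where it says the series, first, only, none or still open, it means among the compounds named here.

Compound 1, with the structure `Nc1cc(N)c2nc(-c3ccccc3)c(Sc3ccc(F)cc3)nc2c1`, was tested in a functional assay on MCF7 cells (Homo sapiens) for inhibition, read by sulforhodamine B assay, with a stated time of 48 h (on this read-out higher numbers stand for weaker inhibition of growth and lower numbers for stronger inhibition of growth), where compound 1 gives 20000 nM. Among the three compounds measured, this is the second highest number. Compound 3, with the structure `CCOC(=O)[C@H](CCC(=O)O)NC(=O)c1ccc(Oc2nc3cc(N)cc(N)c3nc2-c2ccccc2)cc1`, gives in this assay a value of 53700 nM, the nearest to compound 1 and beyond the usual scatter. Compound 2, with the structure `COc1cc(CNc2nc3cc(N)cc(N)c3nc2-c2ccccc2)cc(OC)c1OC`, gives in this assay a value of 1550 nM, the furthest from compound 1 and again beyond the scatter; compound 2 carries a benzylamino type of link to its pendant ring, whereas compound 1 carries a sulfanyl link.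

Compound 4, with the structure `Nc1cc(N)c2nc(-c3ccccc3)c(NCc3ccc(F)cc3)nc2c1`, differs from compound 1 in one place: (4-fluorobenzyl)amino in place of (4-fluorophenyl)sulfanyl on an aromatic carbon. Among the measured compounds shown here, no measured pair shows this exact exchange. Compound 4 is expected to move in the direction of compound 2 because compound 2 shows 1550 nM against compound 1 with 20000 nM, so a step toward stronger inhibition of growth is expected, a 5.0-fold lower number from compound 1 to compound 4 (0.70 log units; beyond the scatter). Compound 4 is therefore estimated at 4000 nM in this assay, with a range from 1000 nM to 15000 nM.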

Compound 4, concentration for 50% growth inhibition: 3020 nM
The estimate for compound 4 lay 1.3-fold (0.12 log units) above the measured number; the measured number falls inside the stated range.
By their numbers in this assay, from the lowest: compounds 2 and 4 (each within the scatter of the next); then compound 1; then compound 3.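

In this assay, among the compounds shown here, replacing (4-fluorophenyl)sulfanyl with (4-fluorobenzyl)amino gives a 6.6-fold lower number from compound 1 to compound 4 (0.82 log units; beyond the scatter) and provides the first comparison that isolates this aromatic carbon, with the shared core and the phenyl group left unchanged. The earlier compounds shown here differed from one another in more than one place, so they could not show that this exchange alone shifts growth inhibition beyond the scatter. Nothing available explains the shift.

The exchange alters the linking atom and adds a carbon between that atom and the fluorinated ring, so its two parts remain unseparated. A (4-fluorophenyl)amino or a (4-fluorobenzyl)sulfanyl group at this position would show how much of the step belongs to each part.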